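The source may hold more compounds than are shown below. What is called first, only, known or untested is meant among the compounds shown, and "the series" means these compounds.

Two members of this series carry a measured number. Compound 1, `O=c1[nH]c(=O)n([C@H]2C[C@H](O)[C@@H](CO)O2)cc1-c1cn(CCC(F)(F)C(F)(F)C(F)(F)C(F)(F)C(F)(F)C(F)(F)C(F)(F)C(F)(F)C(F)(F)C(F)(F)F)nn1`, gives 93.7 uM in a functional assay on MDA-MB-231 cells (Homo sapiens) for antiproliferative activity, read by sulforhodamine B assay; on this read-out lower numbers stand for stronger inhibition of growth and higher numbers for weaker inhibition of growth. Going by the values given here, compound 2, `O=c1[nH]c(=O)n([C@H]2C[C@H](O)[C@@H](CO)O2)cc1-c1cn(CCC(F)(F)C(F)(F)C(F)(F)C(F)(F)C(F)(F)C(F)(F)F)nn1`, is the second measured member; in this assay compound 2 gives 107 uM, the highest of the two numbers, with compound 1 as its only neighbour at a separation that lies within the usual scatter. The two numbers therefore say nothing about order between compound 1 and compound 2; both sit at the weak end of the read-out. Compound 3, `O=c1[nH]c(=O)n([C@H]2C[C@H](O)[C@@H](CO)O2)cc1-c1cn(CCC(F)(F)C(F)(F)C(F)(F)C(F)(F)C(F)(F)C(F)(F)C(F)(F)C(F)(F)F)nn1`, has not yet been measured. It differs from compound 2 in one place: 1,1,2,2,2-pentafluoroethyl in place of fluoro on a saturated chain carbon bound to two fluorine atoms and a saturated chain carbon. The shared core is untouched; only the fluorinated chain changes. Compound 1 and compound 2 give numbers within the scatter of each other although their chains differ, so the change is expected to leave the number where it stands, and the step expected is a 1.1-fold lower number from compound 2 to compound 3 (0.03 log units; within the scatter), none beyond the scatter. For compound 3 the value in this assay is estimated at 100 uM, with a range from 60 uM to 170 uM.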

Compound 3, concentration for growth inhibition (reported as GI): 15.9 uM
Estimate against measurement, compound 3: 6.3-fold (0.80 log units) above; measured number below the stated range.
By their numbers in this assay, from the lowest: compound 3; then compounds 1 and 2 (each within the scatter of the next).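

In this assay the fluorinated chain turns out to be a position where one change moves the number beyond the scatter: adding 1,1,2,2,2-pentafluoroethyl in place of fluoro on the saturated chain carbon bound to two fluorine atoms gives a 6.7-fold lower number from compound 2 to compound 3 (0.83 log units; beyond the scatter) in this series. The same exchange read the other way, fluoro in place of 1,1,2,2,2-pentafluoroethyl, also lowers the number and gives a 5.9-fold lower number from compound 1 to compound 3 (0.77 log units; beyond the scatter) here, so the chain of intermediate length in compound 3 stands below both its shorter and its longer neighbour. The number therefore does not follow chain length in a single direction across these three compounds, a point that compound 1 and compound 2 alone, lying within the scatter of each other, could not show, and nothing available here accounts for this result.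

With only three chain lengths shown, the lowest point is located only roughly, and a chain ending in a trifluoromethyl group with a length lying between those of compound 2 and compound 1 would place it more closely. On these data alone, whether the fluorine atoms matter at all stays open, and a plain unfluorinated alkyl chain of the length in compound 3, or the same chain ending in a carboxylic acid, would address that.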